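Compound 1 to compound 4: hydroxy in place of nitro

The source may hold more compounds than are shown below. What is called first, only, known or untested is meant among the compounds shown, and "the series" means these compounds.

In an ADME assay on HEL cells (Homo sapiens) for cytotoxicity (on this read-out higher numbers stand for lower toxicity in this test and lower numbers for higher toxicity in this test), compound 1 `C/C(=N\NC(=O)COc1cccc2ccccc12)c1ccc([N+](=O)[O-])cc1` gives > 100 ug/mL, which is a limit and not a number. Compound 3 `O=C(COc1cccc2ccccc12)N/N=C/c1c[nH]c2ccccc12` gives > 100 ug/mL, also a limit. Compound 1 therefore sits at the limit of > 100 ug/mL in this assay, at which 2 of the 3 values shown sit. Compound 2 `COc1ccc(/C=N/NC(=O)COc2cccc3ccccc23)cc1OC` alone has a true number, 52.6 ug/mL. Compound 4 `C/C(=N\NC(=O)COc1cccc2ccccc12)c1ccc(O)cc1` carries hydroxy in place of nitro on an aromatic carbon, para to a large group: hydroxy in place of nitro on an aromatic carbon. Among the measured compounds shown here, no measured step covers this change. For the measured compounds named here, with compound 2 at 52.6 ug/mL as the only number, a modest fall toward higher toxicity is expected, possibly none beyond the scatter. The expected change is an at least 1.1-fold lower number from compound 1 to compound 4 (0.07 log units; that floor lies within the scatter). For compound 4 the estimate in this assay is 85 ug/mL, with an expected range of 40 ug/mL to 100 ug/mL.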

Compound 4, half-maximal cytotoxic concentration: 11.1 ug/mL
Estimate against measurement, compound 4: 7.7-fold (0.88 log units) above, and the stated range ends above it.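

At this place on the shared core, an aromatic carbon para to a large group, the substituent matters in this assay: hydroxy in place of nitro gives an at least 9.0-fold lower number from compound 1 to compound 4 (0.95 log units; beyond the scatter), toward higher toxicity in this test. Compound 1 gives > 100 ug/mL, which is a limit. The full size of the step stays unknown because it starts from that limit: the limit of > 100 ug/mL in this assay, at which 2 of the 4 values shown sit.

Whether the loss of nitro or the gain of hydroxy accounts for the step remains open. As far as these compounds go, how an amine or a carboxylic acid at this place would read also remains open.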